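The compounds below may be only part of what the source reports. "The series", "measured", "known", "first", "only" and "open" are said of these compounds alone.

Of the compounds shown here, three built on one shared core have been tested in a functional assay on the whole organism (strain Wistar) for inhibition, with Rattus norvegicus as the target, read by paw edema, with stated times of 60 min and 2 h, at a dose of 100 mg/kg by the oral route; on this read-out higher numbers stand for more inhibition at the one dose given (going by the name of the read-out) and lower numbers for less inhibition. Compound 1 `CCNC(=O)CC1CCc2cc(OC)c(OC)cc21` gives 26%, compound 2 `CCCNC(=O)CC1CCc2cc(OC)c(OC)cc21` gives 28% and compound 3 `COc1cc2c(cc1OC)C(CC(=O)NCc1ccccc1)CC2` gives 24%. Compound 3 stands at the lowest of the three numbers, though a number 2 percentage points lower from compound 1 to compound 3 (within the scatter) and a number 4 percentage points lower from compound 2 to compound 3 (within the scatter) both lie within the scatter, so no order among them can be claimed. Compound 4 `COc1cc2c(cc1OC)C(CC(=O)N1CCCC1)CC2` is the next step: pyrrolidin-1-yl in place of benzylamino on a carbonyl carbon. Among the measured compounds shown here, the steps that bear on it are those at the same amide nitrogen, a number 2 percentage points lower from compound 1 to compound 3 (within the scatter) and a number 4 percentage points lower from compound 2 to compound 3 (within the scatter), which stayed within the scatter even with phenyl in place of methyl or ethyl. For the measured compounds named here, no measured step covers a pyrrolidin-1-yl ring or the loss of the hydrogen-bond donor, so the expectation rests on that pattern alone. Compound 4 is therefore expected to stay close, a step of a number 1 percentage points higher from compound 3 to compound 4 (within the scatter), at an estimated 25% with a range of 14% to 36%.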

Compound 4, a percentage reported as inhibition, in the whole organism at one dose (the size of the read-out at that dose, not a potency): 20%
Estimate against measurement, compound 4: 5 percentage points above, and the stated range covers the measured number.
By their numbers in this assay, from the lowest: compounds 4, 3, 1 and 2 (each within the scatter of the next).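

In this assay, pyrrolidin-1-yl on the carbonyl carbon brings a ring and no amide hydrogen, yet a number 4 percentage points lower from compound 3 to compound 4 (within the scatter) and a number 8 percentage points lower from compound 2 to compound 4 (within the scatter) and a number 6 percentage points lower from compound 1 to compound 4 (within the scatter) all stay within the scatter. So losing the hydrogen-bond donor at this place gives no readable change in these compounds, which the earlier steps could not show. No measurement here accounts for these results.

Still open, from the compounds shown here alone, is whether a morpholin-4-yl ring or a carboxylic acid in place of the amide would move the number beyond the scatter.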